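The source may report more compounds than this note shows. Statements on the series, on what has been measured and on what is new or still open speak of the compounds shown alone.

Measured in a functional assay on MCF7 cells (Homo sapiens) for inhibition, read by MTT assay, with a stated time of 72 h; a higher number here means a weaker inhibitor, a lower number a stronger inhibitor:
- compound 1 `O=C(O)CCCCCCC(=O)Nc1ccc(C2=C(c3ccc(O)cc3)C3CC(S(=O)(=O)Oc4cccc5ccccc45)C2O3)cc1`: 4700 nM
- compound 2 `COc1ccccc1OS(=O)(=O)C1CC2OC1C(c1ccc(NC(=O)CCCCCCC(=O)NO)cc1)=C2c1ccc(O)cc1`: 25800 nM
- compound 3 `O=C(CCCCCCC(=O)Nc1ccc(C2=C(c3ccc(O)cc3)C3CC(S(=O)(=O)Oc4ccc(Br)cc4)C2O3)cc1)NO`: 17100 nM

Compound 1 holds the lowest of the three numbers, and its gaps to the other two lie beyond the scatter. Next in the series is compound 4 `O=C(O)CCCCCCC(=O)Nc1ccc(C2=C(c3ccc(O)cc3)C3CC(S(=O)(=O)Oc4ccc(F)cc4)C2O3)cc1`, with 4-fluorophenyl in place of naphthalen-1-yl on an oxygen. One measured step changes the group at this place, a 1.5-fold lower number from compound 2 to compound 3 (0.18 log units; within the scatter). That step is small, but neither of its compounds carries naphthalen-1-yl, so it bears only indirectly. No large step is expected in this assay, only a slight lean towards a higher number. The expected change is a 1.6-fold higher number from compound 1 to compound 4 (0.20 log units; within the scatter). Compound 4 is estimated at 7500 nM, with an expected range of 2800 nM to 20000 nM.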

Compound 4, half-maximal inhibitory concentration: 24800 nM
Compound 4: middle estimate off by 3.3-fold (0.52 log units), on the low side, and the stated range ends below it.
By their numbers in this assay, from the lowest: compound 1; then compounds 3, 4 and 2 (each within the scatter of the next).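

In this assay the group on the oxygen bound to the sulfonyl sulfur can shift the number beyond the scatter: the change to 4-fluorophenyl from naphthalen-1-yl gives a 5.3-fold higher number from compound 1 to compound 4 (0.72 log units; beyond the scatter) in this series. Among the compounds shown here, the earlier step at this place, a 1.5-fold lower number from compound 2 to compound 3 (0.18 log units; within the scatter) and within the scatter, involved no naphthalen-1-yl, so only this result shows that group's replacement mattering. No evidence at hand bears on the reason for the shift.

Open, from the compounds shown here alone, is whether the second aromatic ring or the fluorine drives the step. Unsubstituted phenyl on the same oxygen would separate the two.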